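The source may hold more compounds than are shown below. What is called first, only, known or untested is meant among the compounds shown, and "the series" means these compounds.

Compound 1 `CCC(CC)/N=C(\NC#N)Nc1ccncc1` and compound 2 `CC(/N=C(\NC#N)Nc1ccncc1)C1CC1` share a core and differ only in the group on a double-bonded nitrogen. In a functional assay on the whole organism (blood, strain Wistar-Okamoto) with Rattus norvegicus as the target, with a stated time of 5 days (on this read-out higher numbers stand for an effect only at larger amounts of compound and lower numbers for an effect already at smaller amounts), compound 1 gives 2.5 mg/kg, and compound 2 gives 3 mg/kg; the step of a 1.2-fold higher number from compound 1 to compound 2 (0.08 log units; within the scatter) is therefore within the scatter. Among the two measured compounds, compound 2 has the highest number, yet its nearest neighbour, compound 1, stands within the scatter of it, so no order can be read between them.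

Compound 3 `N#CN/C(=N\C1CCCCC1)Nc1ccncc1` has not been measured in this assay. The change from compound 2 is cyclohexyl in place of 1-cyclopropylethyl on a double-bonded nitrogen. Going by the values given here, the only measured step that bears on it, the one from compound 1 to compound 2, also exchanged one such group on the same nitrogen and stayed within the scatter. A step of similar size, within the scatter and in no particular direction, is therefore expected for no change at the digits printed from compound 2 to compound 3 (within the scatter). Compound 3 is accordingly estimated at 3 mg/kg, with a range from 1.5 mg/kg to 6 mg/kg.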

Compound 3, minimum effective dose: 20 mg/kg
Estimate against measurement, compound 3: 6.7-fold (0.82 log units) below; measured number outside the range, above it.
By their numbers in this assay, from the lowest: compounds 1 and 2 (each within the scatter of the next); then compound 3.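

In this assay the group on the double-bonded nitrogen proves able to move the number: cyclohexyl in place of 1-cyclopropylethyl gives a 6.7-fold higher number from compound 2 to compound 3 (0.82 log units; beyond the scatter), and cyclohexyl in place of pentan-3-yl gives an 8.0-fold higher number from compound 1 to compound 3 (0.90 log units; beyond the scatter). The earlier exchange at this position stayed within the scatter, so the first two compounds alone gave no sign of this sensitivity, and compound 3 now needs larger amounts for an effect than either of them. Nothing available bears on what lies behind this difference.

As far as these compounds go, what a cyclopentyl group, a tert-butyl group or a longer chain would give on this nitrogen remains open. The compounds shown therefore cannot separate the six-membered ring from the sixth carbon as what goes with the higher number.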